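Pyridinyl triazolyl cyclohexanols: tolerance on Vero cells

The source may hold more compounds than are shown below. What is called first, only, known or untested is meant among the compounds shown, and "the series" means these compounds.

Of the compounds shown here, three have been measured in an ADME assay on Vero cells (Chlorocebus sabaeus) for cytotoxicity, read by MTT assay, with a stated time of 72 h; a lower number here means that less compound is tolerated, a higher number that more compound is tolerated. Compound 1 `OC1(c2nnc(-c3ccncc3)[nH]2)CCCCC1` gives 412 ug/mL in this assay. Compound 2 `OC1(c2nnc(-c3cccnc3)[nH]2)CCCCC1` gives 397 ug/mL in this assay, and the step of a 1.0-fold lower number from compound 1 to compound 2 (0.02 log units; within the scatter) is the change (pyridin-3-yl in place of pyridin-4-yl on an aromatic carbon). Compound 3 `CC1CC(C)(C)CC(O)(c2nnc(-c3ccncc3)[nH]2)C1` gives 414 ug/mL in this assay; its value and those of compound 1 and compound 2 all sit within the scatter of one another, so no order among the three can be read from these data. The difference between the core of compound 3 and the core of compound 1 is not broken down here.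

Compound 4 `CC1CC(C)(C)CC(O)(c2nnc(-c3cccnc3)[nH]2)C1` is not yet measured. It differs from compound 3 by pyridin-3-yl in place of pyridin-4-yl on an aromatic carbon, which is the same kind of change as that from compound 1 to compound 2; the places are not described word for word alike, as the ring atom that bears the pyridinyl carries a group of 7 heavy atoms in compound 1 and a large group in compound 3. Among the measured compounds shown here, since the only measured instance of this change, a 1.0-fold lower number from compound 1 to compound 2 (0.02 log units; within the scatter), lies within the scatter, the step from compound 3 to compound 4 is expected to be of similar size, a 1.0-fold lower number from compound 3 to compound 4 (0.01 log units; within the scatter). Compound 4 is therefore estimated at 400 ug/mL in this assay, with a range from 290 ug/mL to 540 ug/mL, resting on the values of compound 3 and compound 1 and the step between compound 1 and compound 2.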

Compound 4, half-maximal cytotoxic concentration: 368 ug/mL
Compound 4: middle estimate off by 1.1-fold (0.04 log units), on the high side, and the stated range covers the measured number.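

In this assay, pyridin-3-yl in place of pyridin-4-yl on the core of compound 3 gives a 1.1-fold lower number from compound 3 to compound 4 (0.05 log units; within the scatter), so the change leaves no readable mark on this second core. Set beside the step on the core of compound 1, the new step does not differ from it: the same change on two cores in this assay, a 1.0-fold lower number (0.02 log units; within the scatter) from compound 1 to compound 2 and a 1.1-fold lower number (0.05 log units; within the scatter) from compound 3 to compound 4, 1.1-fold (0.04 log units) apart, within the scatter of two such steps. This shows that, on these two cores and in this assay, the change carries over as a step too small to read, but it gives no size or direction for the change, and two cores cannot show that the same would hold on a further core of the series.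

Still open, as far as these compounds go, is whether other groups on the aromatic carbon of the five-membered ring, such as pyridin-2-yl, phenyl, or a pyridine ring bearing an amine or a carboxylic acid, would keep the number in the same range as the two pyridinyl isomers. The shown compounds also leave open how the number responds to replacing the hydroxyl group with a methoxy group or an amine, and to a longer chain on the cyclic part of the core.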